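Saturated acid chain replaces the oxyacetic acid on the core

A few compounds are considered here, and "the series" means these few. Any claim that something is new, unique, unknown or untested is made for them only; others in the source may bear on it.

The series shares one core, carrying a (1H-pyrazol-1-yl)methyl group and a naphthylethoxy group, and varies the acidic arm attached to an aromatic carbon. Compound 1 `O=C(O)/C=C/c1ccc(Cn2cccn2)cc1OCCc1ccc2ccccc2c1` bears a 2-carboxyethenyl arm and in an assay on CHO cells for displacement of a labelled ligand from prostaglandin E2 receptor EP2 subtype (Mus musculus), read by scintillation counting (on this read-out higher numbers stand for weaker inhibition and lower numbers for stronger inhibition), compound 1 gives 3300 nM. Compound 2 `O=C(O)C#Cc1ccc(Cn2cccn2)cc1OCCc1ccc2ccccc2c1` carries a 2-carboxyethynyl arm. In this assay compound 2 returns only a limit, > 10000 nM. Compound 3 `O=C(O)COc1ccc(Cn2cccn2)cc1OCCc1ccc2ccccc2c1` has a carboxymethoxy arm. For compound 3 the assay likewise reports a limit, > 10000 nM. The readable steps are an at least 3.0-fold higher number from compound 1 to compound 2 (0.48 log units; beyond the scatter) and an at least 3.0-fold higher number from compound 1 to compound 3 (0.48 log units; beyond the scatter); the step that the two limits leave unreadable from compound 2 to compound 3 cannot be sized, since both values sit at the limit of > 10000 nM in this assay, at which 2 of the 3 values shown sit.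

Compound 4 `O=C(O)CCCc1ccc(Cn2cccn2)cc1OCCc1ccc2ccccc2c1` is next. Its change from compound 3 is 3-carboxypropyl in place of carboxymethoxy on an aromatic carbon. For the measured compounds named here, of the measured steps, only that from compound 1 to compound 3 bears on it, and only in one direction: the rigid 2-carboxyethenyl arm of compound 1 gave a number, while the carboxymethoxy arm of compound 3 did not. A saturated 3-carboxypropyl arm is new to the set, so the expectation is loose; compound 4 is expected near 5000 nM, within 1500 nM to 20000 nM, which as a step means an at least 2.0-fold lower number from compound 3 to compound 4 (0.30 log units; that floor lies within the scatter), with a real chance that the assay again reports only a limit.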

Compound 4, inhibition constant: 1800 nM
Compound 4: middle estimate off by 2.8-fold (0.44 log units), on the high side; the measured number falls inside the stated range.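

In this assay, the 3-carboxypropyl arm gives a measured number on this aromatic carbon where the carboxymethoxy and 2-carboxyethynyl arms returned only limits, with an at least 5.5-fold lower number from compound 3 to compound 4 (0.74 log units; beyond the scatter) and with an at least 5.5-fold lower number from compound 2 to compound 4 (0.74 log units; beyond the scatter). The 2-carboxyethenyl arm is thus not the only one here to give a measured number: the saturated chain shows a 1.8-fold lower number from compound 1 to compound 4 (0.26 log units; within the scatter), so compound 1 and compound 4 cannot be told apart in this assay. The two larger steps are floors and their full size cannot be read, because each starts from a limit of the assay: the limit of > 10000 nM in this assay, at which 2 of the 4 values shown sit.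

The change from compound 3 to compound 4 alters the chain length and removes the ether oxygen at once, so the compounds shown do not separate these two changes, and a 2-carboxyethyl arm or a carboxyethoxy arm would be needed to do so. They also leave open how a longer chain such as 4-carboxybutyl would read on this carbon, and whether a tetrazole or an amide could stand in place of the carboxylic acid at the end of the 3-carboxypropyl arm.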